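One Added Methyl on the Chain of Compound 1

The source may report more compounds than this note shows. Statements on the series, on what has been measured and on what is new or still open speak of the compounds shown alone.

Among the compounds with values here, in an ADME assay on the whole organism (plasma) for pharmacokinetics, with Rattus norvegicus as the target, at a dose of 5 mg/kg by the oral route (a higher number here means more compound in the circulation at the dose given, a lower number less compound in the circulation), compound 1 `Cc1ccc([C@H](C(=O)N(C)C)N2C(=O)[C@@H](C3Cc4ccccc4C3)NC(=O)[C@H]2CC(C)C)cn1` gives 2680 ng.h/mL, the higher of the two numbers measured so far. Compound 2 `CC(C)C[C@@H]1C(=O)N[C@H](C2Cc3ccccc3C2)C(=O)N1[C@@H](C(=O)N(C)C)c1ccc(N(C)C)nc1`, with dimethylamino in place of methyl on an aromatic carbon, gives 135 ng.h/mL. Compound 3 `Cc1ccc([C@H](C(=O)N(C)C)N2C(=O)[C@@H](C3Cc4ccccc4C3)NC(=O)[C@H]2CC(C)(C)C)cn1` keeps the core of compound 1 and carries methyl in place of hydrogen on a saturated chain carbon bound to three saturated chain carbons, so that isobutyl becomes neopentyl: methyl in place of hydrogen on a saturated chain carbon bound to three saturated chain carbons. Within the data shown here, the one measured step, a 20-fold lower number from compound 1 to compound 2 (1.30 log units; beyond the scatter), lies on an aromatic carbon and not on this chain. It shows that a single change can move this assay a long way, but it gives neither a size nor a direction for the new change. Among the measured compounds shown here, no measurement yet tests this chain, so no step beyond the scatter is expected, in either direction, and the range is kept wide. The expected step is a 1.1-fold lower number from compound 1 to compound 3 (0.05 log units; within the scatter). For compound 3 the estimate is 2400 ng.h/mL, with an expected range from 800 ng.h/mL to 7000 ng.h/mL.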

Compound 3, area under the concentration-time curve: 618 ng.h/mL
Estimate against measurement, compound 3: 3.9-fold (0.59 log units) above; measured number outside the range, below it.
By their numbers in this assay, from the lowest: compound 2; then compound 3; then compound 1.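

The chain position is not silent in this assay: turning isobutyl into neopentyl gives a 4.3-fold lower number from compound 1 to compound 3 (0.64 log units; beyond the scatter) even though the entering methyl is one carbon, with no ring, no hydrogen-bond donors or acceptors and no net charge. Until now only a change on an aromatic carbon had been seen to move this number, and this saturated chain carbon is now a second place where a single change takes the number beyond the scatter, again downward, so compound 1 remains the highest of the three compounds. The compounds come with no evidence that would account for this drop.

What the compounds shown leave open is how the number responds to other groups at this position, such as a shorter ethyl chain, a cyclopropylmethyl group or a chain carrying a hydroxyl group. Also open, from the compounds shown here alone, is how neopentyl behaves together with dimethylamino on the aromatic carbon, as these two changes appear here only on separate compounds.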